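The compounds below may be only part of what the source reports. "The series", "measured", "known", "first", "only" and "open" are said of these compounds alone.

Three members of this series have so far been tested in an ADME assay on the whole organism for cytotoxicity, with Artemia salina as the target, with a stated time of 24 h; on this read-out higher numbers stand for an effect only at larger amounts of compound and lower numbers for an effect already at smaller amounts. Compound 1 `COc1cccc(/C=C/C(=O)c2ccccc2NC(=O)NS(=O)(=O)c2ccc(C)cc2)c1` gives 23.2 ug/mL in this assay. Compound 2 `CCc1cc(/C=C/C(=O)c2ccccc2NC(=O)NS(=O)(=O)c2ccc(C)cc2)cc(OC)c1OC` gives 19.2 ug/mL, and the step of a 1.2-fold lower number from compound 1 to compound 2 (0.08 log units; within the scatter) stays within the scatter. Compound 3 `Cc1ccc(S(=O)(=O)NC(=O)Nc2ccccc2C(=O)/C=C/c2cccc(F)c2)cc1` gives 4.13 ug/mL, the lowest of the three numbers; the steps of a 5.6-fold lower number from compound 1 to compound 3 (0.75 log units; beyond the scatter) and a 4.6-fold lower number from compound 2 to compound 3 (0.67 log units; beyond the scatter) both lie beyond the scatter.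

Compound 4 `C=CCOc1ccc(/C=C/C(=O)c2ccccc2NC(=O)NS(=O)(=O)c2ccc(C)cc2)cc1` is the next to be tested. It differs from compound 3 in one place: 4-(allyloxy)phenyl in place of 3-fluorophenyl on a double-bonded chain carbon bound to a double-bonded chain carbon. Among the measured compounds shown here, two measured steps bear on this change. Both a 5.6-fold lower number from compound 1 to compound 3 (0.75 log units; beyond the scatter) and a 4.6-fold lower number from compound 2 to compound 3 (0.67 log units; beyond the scatter) exchange an aryl carrying methoxy groups for the 3-fluorophenyl at the same place on the chain, and both lower the number by a modest amount. Compound 4 reverses the direction of that exchange, replacing the 3-fluorophenyl with an aryl that again carries an alkoxy substituent, here 4-(allyloxy)phenyl. For the measured compounds named here, the expectation is therefore a modest rise in this assay, back toward the numbers of compounds 1 and 2, though the allyloxy group has no measured precedent here. The estimated step is a 3.6-fold higher number from compound 3 to compound 4 (0.56 log units; beyond the scatter). Compound 4 is expected to give about 15 ug/mL, within a range from 6 ug/mL to 35 ug/mL.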

Compound 4, concentration for half-maximal effect: 6.11 ug/mL
Compound 4: middle estimate off by 2.5-fold (0.39 log units), on the high side, and the stated range covers the measured number.
By their numbers in this assay, from the lowest: compounds 3 and 4 (each within the scatter of the next); then compounds 2 and 1 (each within the scatter of the next).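

In this assay, putting 4-(allyloxy)phenyl in place of 3-fluorophenyl on a double-bonded chain carbon bound to a double-bonded chain carbon gives a 1.5-fold higher number from compound 3 to compound 4 (0.17 log units; within the scatter) and so leaves the two compounds together, which shows that an aryl carrying an oxygen-linked group at this position does not by itself go with the higher numbers of compounds 1 and 2. The same group also separates compound 4 from those two, with a 3.1-fold lower number from compound 2 to compound 4 (0.50 log units; beyond the scatter) and a 3.8-fold lower number from compound 1 to compound 4 (0.58 log units; beyond the scatter), so the divide that had looked like one between fluoro and alkoxy groups now runs among the alkoxy-bearing aryl groups themselves. Nothing in the available data accounts for this difference among them.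

The 4-(allyloxy)phenyl and 3-methoxyphenyl groups differ in both the chain and where it sits on the ring, so the compounds shown cannot say which of these separates compound 4 from compound 1. As far as these compounds go, it also remains open how this position would respond to a saturated propyloxy chain in place of allyloxy, or to an amine or a carboxylic acid on the aryl ring.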